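Ester aryl variation on the shared core

This account rests on a few compounds, and the source may have more. Where it says the series, first, only, none or still open, it means among the compounds named here.

Measured so far:
In a functional assay on U-251 cells (Homo sapiens) for antiproliferative activity, read by sulforhodamine B assay, with a stated time of 48 h, tested at 50 uM (a higher number here means more inhibition at the concentration tested (going by the name of the read-out), a lower number less inhibition), compound 1 `CC1=CC[C@H](C(C)C)c2cc(C)c(OC(=O)c3ccc(C)cc3)cc21` gives 67.7%.
In this assay compound 2 `CC1=CC[C@H](C(C)C)c2cc(C)c(OC(=O)c3ccccc3)cc21` gives 25.8%.
In this assay compound 3 `CC1=CC[C@H](C(C)C)c2cc(C)c(OC(=O)c3ccc(Cl)cc3)cc21` gives 25.6%.

Compound 3 shows the lowest number of the three. The step of a number 0.2 percentage points lower from compound 2 to compound 3 (within the scatter) is within the scatter, so compound 2 and compound 3 cannot be told apart on these numbers. The step of a number 42.1 percentage points lower from compound 1 to compound 3 (beyond the scatter) is large and beyond the scatter, as is the step of a number 41.9 percentage points lower from compound 1 to compound 2 (beyond the scatter); only the methyl-bearing ester of compound 1 stands out, and nothing in the three compounds says whether other groups on that ring would move the number.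

Compound 4 `CC1=CC[C@H](C(C)C)c2cc(C)c(OC(=O)c3cccc([N+](=O)[O-])c3)cc21` differs from compound 3 by 3-nitrophenyl in place of 4-chlorophenyl on a carbonyl carbon. Among the measured compounds shown here, no measured step exchanges one substituted phenyl for another substituted phenyl, and none involves a nitro group. The closest bearing is that chloro in place of hydrogen made no difference, while methyl in place of hydrogen made a large one. For the measured compounds named here, with no directly comparable step, the expected change from compound 3 to compound 4 in this assay is none beyond the scatter, a number 4.4 percentage points higher from compound 3 to compound 4 (within the scatter), with a wide spread allowed in either direction. For compound 4 the estimated value is 30%, expected to fall between 10% and 60%.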

Compound 4, a percentage reported as inhibition, at one concentration (the size of the read-out at that concentration, not a potency): 44%
Compound 4: the middle estimate sits 14 percentage points below what was measured, within the range that was stated.
By their numbers in this assay, from the lowest: compounds 3 and 2 (each within the scatter of the next); then compound 4; then compound 1.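

In this assay, among the compounds shown here, the aryl group on the carbonyl carbon now shows a second substituent that lifts the number above the level of the unsubstituted phenyl ester: nitro in place of hydrogen gives a clear change (a number 18.2 percentage points higher from compound 2 to compound 4 (beyond the scatter)), so methyl is no longer the only group that does so. The exchange of 4-chlorophenyl for 3-nitrophenyl reads the same way (a number 18.4 percentage points higher from compound 3 to compound 4 (beyond the scatter)), yet 3-nitrophenyl does not reach the level of 4-methylphenyl (a number 23.7 percentage points lower from compound 1 to compound 4 (beyond the scatter)), which places compound 4 in an intermediate rank and leaves compound 1 highest of the four. No measurement at hand accounts for any of these differences.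

On these data alone, whether the change belongs to the nitro group itself or to where it sits stays open, since compound 4 alone carries a 3-substituted phenyl, while compound 1 and compound 3 carry 4-substituted ones. The compounds shown also do not tell how an amine, a carboxylic acid, a methoxy group or a longer alkyl chain on that phenyl ring would read.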